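Compound 2 gives up its 3-methoxyphenyl group

The compounds below may be only part of what the source reports. "The series", "measured", "known", "first", "only" and "open" are said of these compounds alone.

In a functional assay on MCF7 cells (Homo sapiens) for cytotoxicity, read by MTT assay, with a stated time of 72 h (a higher number here means a weaker inhibitor, a lower number a stronger inhibitor), compound 1 `COc1cccc(/C=C2\CCC/C(=C\c3ccc(Br)cc3)C2=O)c1OC` gives 13800 nM, while compound 2 `COc1cccc(/C=C2\CCC/C(=C\c3cccc(OC)c3OC)C2=O)c1` gives 5900 nM, the lower of the two numbers. Compound 3 `COc1cccc(/C=C2\CCC/C(=C\c3ccc(O)cc3)C2=O)c1OC` is the next to be measured. It has 4-hydroxyphenyl in place of the 3-methoxyphenyl of compound 2, on a double-bonded chain carbon bound to a double-bonded ring carbon (4-hydroxyphenyl in place of 3-methoxyphenyl on a double-bonded chain carbon bound to a double-bonded ring carbon). Within the data shown here, one measured step bears on this place: a 2.3-fold lower number from compound 1 to compound 2 (0.37 log units; beyond the scatter), a modest change that brought in 3-methoxyphenyl in place of 4-bromophenyl. Among the measured compounds shown here, compound 3 gives that group up again, but no measured compound carries 4-hydroxyphenyl, so the guide is weak. In this assay, a small move towards a higher number is therefore expected, a 1.5-fold higher number from compound 2 to compound 3 (0.18 log units; within the scatter). The estimated value for compound 3 is 9000 nM, with an expected range of 3500 nM to 22000 nM.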

Compound 3, half-maximal inhibitory concentration: > 20000 nM
Compound 3: no number, only a limit; the forecaster's own chance of this, stated with the estimate: 5%; at least 2.2-fold (0.34 log units) between middle value and limit.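

In this assay compound 3 carries a limit and not a number: the limit of > 20000 nM in this assay, at which 1 of the 3 values shown sits. Even with only that limit, the position on a double-bonded chain carbon bound to a double-bonded ring carbon proves able to lose activity as well as gain it, since 4-hydroxyphenyl in place of 3-methoxyphenyl gives an at least 3.3-fold higher number from compound 2 to compound 3 (0.53 log units; beyond the scatter). Hydroxy in place of bromo on an aromatic carbon gives an at least 1.4-fold higher number from compound 1 to compound 3 (0.16 log units; that floor lies within the scatter), so compound 3 cannot be firmly placed against compound 1, and the hydroxy group shows no sign of matching the bromo group.

Going by these compounds, how far the true value of compound 3 lies past its limit stays open. So does whether an amine or a carboxylic acid in place of the hydroxy group would leave the number as high or bring it down again.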